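The compounds below may be only part of what the source reports. "The series", "measured", "known", "first", "only" and "open" are said of these compounds alone.

Working notes on the series. Compound 1 `C=CCCC(=O)N[C@H]1[C@@H](OCCc2ccccc2)O[C@H](CO)[C@@H](O)[C@@H]1O` gives only a limit in a functional assay on A-375 cells (Homo sapiens), read by thymidine incorporation (a higher number here means a weaker inhibitor, a lower number a stronger inhibitor), namely > 50 uM. Compound 2 `CCCCC(=O)N[C@H]1[C@@H](OCCc2ccccc2)O[C@H](COCC(CO)(CO)COS(=O)(=O)O)[C@@H](O)[C@@H]1O` gives 9.3 uM in this assay. Compound 3 `CCCCC(=O)N[C@H]1[C@@H](OCCc2ccccc2)O[C@H](COCC(CO)(CO)CO)[C@@H](O)[C@@H]1O` likewise reaches only a limit in this assay, > 50 uM, so its true value is not known; both limits sit at the limit of > 50 uM in this assay, at which 2 of the 3 values shown sit. For the measured compounds named here, the one measured step, an at least 5.3-fold higher number from compound 2 to compound 3 (0.73 log units; beyond the scatter), is the sole change recorded. Going by the values given here, compound 4 `CCCCC(=O)N[C@H]1[C@@H](OCCc2ccccc2)O[C@H](COCC(O)CO)[C@@H](O)[C@@H]1O` differs from compound 3 by 1,2-dihydroxyethyl in place of 2-hydroxy-1,1-bis(hydroxymethyl)ethyl on a saturated chain carbon bound to an oxygen on a saturated carbon; the sulfo group is absent in both, and no measured step alters the polyol size. The expected change for compound 4 is therefore none beyond the scatter, a step that the limit leaves unreadable from compound 3 to compound 4, most probably another limit. Compound 4 is estimated at 80 uM, range 30 uM to 250 uM.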

Compound 4, concentration for 50% inhibition: > 50 uM
Compound 4: only a limit was reported; the forecaster's own chance of this, stated with the estimate: 80%; the middle value does not contradict the limit.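

On this saturated chain carbon, 1,2-dihydroxyethyl in place of 2-hydroxy-1-(hydroxymethyl)-1-((sulfooxy)methyl)ethyl gives an at least 5.3-fold higher number from compound 2 to compound 4 (0.73 log units; beyond the scatter) in this assay, so the smaller polyol without a sulfo group behaves like the larger one in lying beyond the sulfated compound. Compound 4 gives > 50 uM, which is a limit and not a number. The step between the two unsulfated polyols cannot be read, because both stop at the same limit: the limit of > 50 uM in this assay, at which 3 of the 4 values shown sit.

As far as these compounds go, what a carboxylic acid or a phosphate on the same chain would give stays open. So does the effect of polyol size when a sulfo group is present.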